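This account rests on a few compounds, and the source may have more. Where it says the series, first, only, none or still open, it means among the compounds named here.

Measured in a functional assay on A498 cells (Homo sapiens) for cytotoxicity; a higher number here means a weaker inhibitor of growth, a lower number a stronger inhibitor of growth:
- Compound 1 `COc1ccc(C2=C(c3ccc(SC)cc3)CC3CCCN3C2=O)cc1Br`: 600 nM
- Compound 2 `CSc1ccc(C2=C(c3ccc(OCC4CO4)cc3)C(=O)N3CCCC3C2)cc1`: 500 nM

Compound 2, at 500 nM, and compound 1, at 600 nM, lie within the scatter of each other, so these two numbers set no order. Together they place the series so far in a single narrow band of growth inhibition.

The next compound to be read is compound 3 `CSc1ccc(C2=C(c3ccc(F)cc3)C(=O)N3CCCC3C2)cc1`. It keeps the shared core of compound 2 and has fluoro in place of (oxiran-2-yl)methoxy on an aromatic carbon, para to a large group (fluoro in place of (oxiran-2-yl)methoxy on an aromatic carbon). Within the data shown here, no measured step at this place is available, and the two values in hand come from compounds that differ in more than one place. The expectation therefore rests on the size of the structural change alone and stays loose. A modest move toward a higher number in this assay is expected, though a result within the scatter would not be surprising. The expected step is a 2.0-fold higher number from compound 2 to compound 3 (0.30 log units; within the scatter). For compound 3 the estimated value is 1000 nM, with an expected range of 250 nM to 5000 nM.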

Compound 3, concentration for 50% growth inhibition: 100 nM
Compound 3: the middle estimate sits 10-fold (1.00 log units) above what was measured; measured number below the stated range.
By their numbers in this assay, from the lowest: compound 3; then compounds 2 and 1 (each within the scatter of the next).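

In this assay, among these compounds, fluoro in place of (oxiran-2-yl)methoxy on an aromatic carbon, para to a large group, gives a 5.0-fold lower number from compound 2 to compound 3 (0.70 log units; beyond the scatter) and so separates compound 3 from the band that held the earlier compounds. Among the compounds shown here, this is the first single-place change to move the number beyond the scatter, and the smaller group is the one with the lower number: one heavy atom and no ring in compound 3, against 5 heavy atoms and a three-membered ring in compound 2. The change of 4-fluorophenyl in place of 3-bromo-4-methoxyphenyl on a double-bonded ring carbon gives a 6.0-fold lower number from compound 1 to compound 3 (0.78 log units; beyond the scatter) of similar size, but no measurement on hand explains either step.

The compounds shown leave open whether the lower number belongs to fluoro itself or simply to the loss of the (oxiran-2-yl)methoxy group. A hydroxy group, a chlorine atom or an amine on the same aromatic carbon would help to separate these two readings, and whether the three-membered ring matters at all remains unresolved.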